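Varying the amide acyl group on a shared sulfonate core

A few compounds are considered here, and "the series" means these few. Any claim that something is new, unique, unknown or untested is made for them only; others in the source may bear on it.

Measured so far:
compound 1 `CC(=O)Nc1cccc(S(=O)(=O)Oc2ccccc2C(C)C)c1` gives 27000 nM in a functional assay on HT-29 cells (Homo sapiens) for antiproliferative activity, read by sulforhodamine B assay, with a stated time of 48 h; on this read-out lower numbers stand for stronger inhibition and higher numbers for weaker inhibition
compound 2 `CCCCCC(=O)Nc1cccc(S(=O)(=O)Oc2ccccc2C(C)C)c1` gives 19000 nM in this assay
compound 3 `CC(C)c1ccccc1OS(=O)(=O)c1cccc(NC(=O)C(C)(C)C)c1` gives 19000 nM in this assay

Compound 3 stands level with compound 2 at the digits shown, the two together the lowest of the three numbers, and a 1.4-fold lower number from compound 1 to compound 3 (0.15 log units; within the scatter). The other two steps tell the same story: a 1.4-fold lower number from compound 1 to compound 2 (0.15 log units; within the scatter), and no change at the digits printed from compound 2 to compound 3 (within the scatter). Every change on the carbonyl carbon in this set has stayed within the scatter of this assay.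

Compound 4 `CC(C)c1ccccc1OS(=O)(=O)c1cccc(NC(=O)CCl)c1` carries chloromethyl in place of tert-butyl on a carbonyl carbon. Within the data shown here, no measured step brings in a chloromethyl, so the three acyl changes above are the only guide, and all three were within the scatter. The expected step from compound 3 to compound 4 is therefore a 1.1-fold higher number from compound 3 to compound 4 (0.02 log units; within the scatter), nothing beyond the scatter. Compound 4 is estimated to give 20000 nM in this assay, within a range from 8000 nM to 50000 nM.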

Compound 4, half-maximal inhibitory concentration: 4500 nM
Beside the measured number, compound 4's estimate is 4.4-fold (0.65 log units) above it; the whole stated range lies above it.
By their numbers in this assay, from the lowest: compound 4; then compounds 2, 3 and 1 (each within the scatter of the next).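

Chloromethyl is the first group on this carbonyl carbon to move the number beyond the scatter in this assay, giving a 4.2-fold lower number from compound 3 to compound 4 (0.63 log units; beyond the scatter) and a 4.2-fold lower number from compound 2 to compound 4 (0.63 log units; beyond the scatter) and also a 6.0-fold lower number from compound 1 to compound 4 (0.78 log units; beyond the scatter) in this set. Compound 4 therefore stands apart from all three compounds with a plain alkyl group on the carbonyl carbon, which remain within the scatter of one another. Nothing measured here accounts for this drop.

Going by these compounds, whether a bromomethyl or methoxymethyl group on the carbonyl carbon would give a similar number remains open. So does whether the chlorine or the shorter chain matters, since a comparison with an ethyl group is not among the compounds shown.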